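This account rests on a few compounds, and the source may have more. Where it says the series, first, only, none or still open, it means among the compounds named here.

Measured compounds in an ADME assay on Huh-7 cells (Homo sapiens) for cytotoxicity, read by MTT assay, with a stated time of 72 h; on this read-out lower numbers stand for higher toxicity in this test and higher numbers for lower toxicity in this test:
- compound 1, `O=C(NO)c1cccc(Cl)c1`, gives 120000 nM
- compound 2, `O=C(NO)c1cccc(Br)c1`, gives 310000 nM
- compound 3, `O=C(NO)c1ccc(Cl)cc1`, gives 55000 nM

Compound 1 and compound 2 share a core and differ by one change, (bromo in place of chloro on an aromatic carbon). That change made a 2.6-fold higher number from compound 1 to compound 2 (0.41 log units; beyond the scatter) in this assay, a modest step and beyond the scatter.

Compound 3 has the lowest number of the three in this assay; its nearest neighbour is compound 1 and its furthest is compound 2. Compound 3 and compound 1 are built from the same atoms joined differently, and the difference between the two cores is not broken down here.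

Compound 4, `O=C(NO)c1ccc(Br)cc1`, is not yet measured. It differs from compound 3 by bromo in place of chloro on an aromatic carbon. Among the compounds with values here, this is the same kind of change as the one from compound 1 to compound 2, not the same one: in compound 1 the halogen sits meta to a group of 4 heavy atoms, in compound 3 it sits para to that group. The change occurs in two pairs among the compounds here, and only one of them is measured.

In this assay, within the data shown here, the step from compound 3 to compound 4 is expected to be a 2.4-fold higher number from compound 3 to compound 4 (0.37 log units; beyond the scatter), set beside a 2.6-fold higher number from compound 1 to compound 2 (0.41 log units; beyond the scatter), because the measured pair gave a 2.6-fold higher number from compound 1 to compound 2 (0.41 log units; beyond the scatter) and no second measured pair is available to check whether the step repeats at the other place. The expectation for compound 4 in this assay is therefore 130000 nM, with a range from 50000 nM to 350000 nM.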

Compound 4, half-maximal cytotoxic concentration: 25000 nM
The estimate for compound 4 lay 5.2-fold (0.72 log units) above the measured number, and the stated range ends above it.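

In this assay, bromo in place of chloro on an aromatic carbon does not carry over from one core to the other, and the two steps differ in direction as well as in size: the same change on two cores in this assay, a 2.6-fold higher number (0.41 log units; beyond the scatter) from compound 1 to compound 2 and a 2.2-fold lower number (0.34 log units; beyond the scatter) from compound 3 to compound 4, 5.7-fold (0.75 log units) apart, beyond the scatter of two such steps. With the halogen para to a group of 4 heavy atoms, the change gives a 2.2-fold lower number from compound 3 to compound 4 (0.34 log units; beyond the scatter), so the step of a 2.6-fold higher number from compound 1 to compound 2 (0.41 log units; beyond the scatter) is no guide to its size or direction on the core of compound 3. Within the data shown here, this shows that, in this series and in this test, the effect of the exchange depends on the core that carries it, but it rests on only two pairs and does not show what in the cores sets the difference, nor how the exchange would behave on any further core.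

From the compounds shown here alone, it remains open whether fluoro, iodo or methyl on the same aromatic carbon would follow the order seen on the core of compound 1, the order seen on the core of compound 3, or neither. Going by these compounds, it is equally open whether the opposite steps would persist if a carboxylic acid or a primary amide stood in place of the group of 4 heavy atoms.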